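A Tosylate Replaces the Triazolylthio Group in This Series

This account rests on a few compounds, and the source may have more. Where it says the series, first, only, none or still open, it means among the compounds named here.

Measured compounds:
Compound 1 `O=[N+]([O-])c1ccc(-c2nc(CO[C@@H]3O[C@H](CO)[C@H]4OC5(CCCC5)O[C@@H]34)no2)cc1`: 50000 nM
Compound 2 `O=[N+]([O-])c1ccc(-c2nc(CO[C@@H]3O[C@H](CSc4ncn[nH]4)[C@H]4OC5(CCCC5)O[C@@H]34)no2)cc1`: 20000 nM

In a functional assay on T47D cells (Homo sapiens) for antiproliferative activity, read by sulforhodamine B assay, with a stated time of 48 h (a higher number here means a weaker inhibitor of growth, a lower number a stronger inhibitor of growth), compound 1 gives 50000 nM and compound 2 gives 20000 nM. Among the compounds with values here, compound 2 holds the lower of the two numbers; its only neighbour is compound 1, and the single measured step, a 2.5-fold lower number from compound 1 to compound 2 (0.40 log units; beyond the scatter), shows that exchanging the group at this position can move the number beyond the scatter, though only modestly.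

Compound 3 `Cc1ccc(S(=O)(=O)OC[C@H]2O[C@@H](OCc3noc(-c4ccc([N+](=O)[O-])cc4)n3)[C@@H]3OC4(CCCC4)O[C@@H]32)cc1` differs from compound 2 by ((4-methylphenyl)sulfonyl)oxy in place of (1H-1,2,4-triazol-5-yl)sulfanyl on a saturated chain carbon bound to a saturated ring carbon. Within the data shown here, the step from compound 1 to compound 2 bears on this change only in that it altered the same position; the group now entering is unrelated to either group seen before, so no measured step tells its direction. The account therefore expects a step around a 1.3-fold lower number from compound 2 to compound 3 (0.12 log units; within the scatter) for compound 3, that is, nothing clearly beyond the scatter in either direction. Compound 3 is thus expected to give about 15000 nM in this assay, with a range from 5000 nM to 50000 nM.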

Compound 3, concentration for 50% growth inhibition: > 100000 nM
Compound 3 was reported as a limit; the forecaster's own chance of this, stated with the estimate: 20%; middle value at least 6.6-fold (0.82 log units) from the limit.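

In this assay compound 3 is reported only as a limit, not as a number: the limit of > 100000 nM in this assay, at which 1 of the 3 values shown sits.

The earlier step showed only a modest move towards a lower number, with a 2.5-fold lower number from compound 1 to compound 2 (0.40 log units; beyond the scatter). This change shows that the same position can also move the number the other way and further, since ((4-methylphenyl)sulfonyl)oxy in place of (1H-1,2,4-triazol-5-yl)sulfanyl gives an at least 5.0-fold higher number from compound 2 to compound 3 (0.69 log units; beyond the scatter). Set against the hydroxy parent, the same group gives an at least 2.0-fold higher number from compound 1 to compound 3 (0.30 log units; that floor lies within the scatter), so this comparison does not firmly separate the two compounds, and only the comparison with the triazolylsulfanyl compound clearly shows the loss.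

The compounds shown leave open how far compound 3 really lies from the others, and whether the ring, the sulfonyl group or the oxygen link in the entering group accounts for the change. They also leave open where an amine, a carboxylic acid or a plain methylsulfanyl group on this chain carbon would fall relative to the hydroxy and triazolylsulfanyl compounds.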